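This account rests on a few compounds, and the source may have more. Where it says the series, first, only, none or still open, it means among the compounds named here.

Measured so far in a functional assay on SW480 cells (Homo sapiens) for antiproliferative activity, read by sulforhodamine B assay, with a stated time of 48 h; a lower number here means a stronger inhibitor, a higher number a weaker inhibitor:
- compound 1 `COc1ccc(OC)c(/C=C/C(=O)/C=C(O)/C=C/c2cc(OC)ccc2OC)c1` gives 15600 nM
- compound 2 `COc1ccc(C=C(C(=O)/C=C/c2cccc(OC)c2OC)C(=O)/C=C/c2cccc(OC)c2OC)cc1OC` gives 410 nM

Of these two numbers compound 2 holds the lower, and its gap to compound 1 lies beyond the scatter. Compound 3 `COc1cccc(/C=C/C(=O)C(=Cc2ccc(O)c(F)c2)C(=O)/C=C/c2cccc(OC)c2OC)c1OC` has not yet been measured. It differs from compound 2 in one place: 3-fluoro-4-hydroxyphenyl in place of 3,4-dimethoxyphenyl on a double-bonded chain carbon bound to a double-bonded chain carbon. Within the data shown here, no measured pair shows this exchange, so the expectation rests on little. In this assay a small shift toward a lower number is expected, with no step beyond the scatter. The estimated change is a 1.4-fold lower number from compound 2 to compound 3 (0.14 log units; within the scatter) on this reading. For compound 3 the estimated value is 300 nM with an expected range from 80 nM to 1100 nM for now.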

Compound 3, half-maximal inhibitory concentration: 330 nM
Compound 3: middle estimate off by 1.1-fold (0.04 log units), on the low side; the measured number falls inside the stated range.
By their numbers in this assay, from the lowest: compounds 3 and 2 (each within the scatter of the next); then compound 1.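

In this assay, 3-fluoro-4-hydroxyphenyl in place of 3,4-dimethoxyphenyl on a double-bonded chain carbon bound to a double-bonded chain carbon gives a 1.2-fold lower number from compound 2 to compound 3 (0.09 log units; within the scatter), so this position accepts the exchange with no step beyond the scatter. The exchange brings in a hydrogen-bond donor and a fluorine at once, and this single pair cannot separate what each contributes. Nothing at hand speaks to why the two compounds read alike.

On these data alone, how the hydroxyl and the fluorine count alone stays open; a 4-hydroxyphenyl or a 3-fluorophenyl in this place would speak to that. Also open, as far as these compounds go, is whether the position stays this even for a more different group, such as a phenyl carrying an amine or a carboxylic acid.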